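A few compounds are considered here, and "the series" means these few. Any claim that something is new, unique, unknown or untested is made for them only; others in the source may bear on it.

Measured compounds:
compound 1, `Cc1nc(-c2ccccc2)c(C(=O)N2CCN(c3cccc(C(N)=O)c3)CC2)o1`: 71 nM
compound 2, `COc1cccc(N2CCN(C(=O)c3oc(C)nc3-c3ccccc3F)CC2)c1`: 56.1 nM

Both were tested in a functional assay on HL-60 cells (Homo sapiens) for inhibition, read by MTT assay, with a stated time of 72 h; a lower number here means a stronger inhibitor, a higher number a weaker inhibitor. Compound 1 gives the higher of the two numbers, but compound 2 lies within the usual scatter of it, so the two cannot be told apart on these data. Compound 3, `COc1cc(OC)cc(N2CCN(C(=O)c3oc(C)nc3-c3ccccc3)CC2)c1`, has not yet been measured. It shares its core with compound 1 and differs from it in one place: 3,5-dimethoxyphenyl in place of 3-carbamoylphenyl on an amine nitrogen in a ring. Among the compounds with values here, no step between measured compounds that differ in only one place is known, so nothing shows directly how much a change at this position moves the number. Compound 2 differs from compound 1 in several places. In this assay compound 2 gives 56.1 nM, a number close to that of compound 1. On that basis the step of a 1.0-fold lower number from compound 1 to compound 3 (0.01 log units; within the scatter) is expected to be none beyond the scatter. Compound 3 is therefore estimated at 70 nM, within a range from 25 nM to 200 nM.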

Compound 3, half-maximal inhibitory concentration: 19.2 nM
Compound 3: middle estimate off by 3.6-fold (0.56 log units), on the high side, outside the stated range (below it).
By their numbers in this assay, from the lowest: compound 3; then compounds 2 and 1 (each within the scatter of the next).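

In this assay, within the data shown here, placing 3,5-dimethoxyphenyl where 3-carbamoylphenyl stood on the amine nitrogen in the ring gives a 3.7-fold lower number from compound 1 to compound 3 (0.57 log units; beyond the scatter) and so shows that the group at this position can move the number, which the earlier compounds could not show. The hydrogen-bond donor of 3-carbamoylphenyl is not required for a low number in this series, as 3,5-dimethoxyphenyl has none. No measurement available here explains why the number falls.

Going by these compounds, whether the step comes from gaining the two methoxy groups or from losing the carbamoyl group stays open, as compound 2 differs from compound 1 in several places and cannot separate the two. The compounds shown also leave open how a phenyl ring carrying an amine or a carboxylic acid would behave at this position.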